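A few compounds are considered here, and "the series" means these few. Any claim that something is new, unique, unknown or untested is made for them only; others in the source may bear on it.

Compound 2 `COc1cc2c(Oc3ccc(NC(=O)c4nc(-c5ccc(F)cc5)no4)cc3)ccnc2cc1OCCCN1CCC(C)CC1` stands lowest of the three numbers in a functional assay on PC-3 cells (Homo sapiens) for antiproliferative activity, read by MTT assay, with a stated time of 72 h (a higher number here means a weaker inhibitor, a lower number a stronger inhibitor), giving 1040 nM. Compound 3 `COc1cc2c(Oc3ccc(NC(=O)c4nnc(-c5ccc(F)cc5)o4)cc3)ccnc2cc1OCCCN1CCC(C)CC1` gives 3810 nM in this assay, a step of a 3.7-fold higher number from compound 2 to compound 3 (0.56 log units; beyond the scatter). Compound 1 `COc1cc2nccc(Oc3ccc(NC(=O)c4ncc(-c5ccc(F)cc5)o4)cc3)c2cc1OC` differs from compound 2 in two places at once; in this assay compound 1 gives 21900 nM.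

Compound 4 `COc1cc2nccc(Oc3ccc(NC(=O)c4nc(-c5ccc(F)cc5)no4)cc3)c2cc1OC` is compound 2 with hydrogen in place of 2-(4-methylpiperidin-1-yl)ethyl on a saturated chain carbon bound to an oxygen on an aromatic ring. Within the data shown here, no measured single step covers this change. Among the measured compounds shown here, the only guide is that compound 1, which also lacks the side chain, shows the highest number in this assay, and that compound 2, which carries it, shows the lowest. A rise beyond the scatter is therefore expected, with the step from compound 2 to compound 4 estimated as a 7.7-fold higher number from compound 2 to compound 4 (0.89 log units; beyond the scatter). For compound 4 the expected value in this assay is 8000 nM, with a range of 2500 nM to 25000 nM.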

Compound 4, half-maximal inhibitory concentration: > 100000 nM
Compound 4 gave a limit, no number; the forecaster's own chance of this, stated with the estimate: 10%; middle value at least 12-fold (1.09 log units) away from the limit.
By their numbers in this assay, from the lowest: compound 2; then compound 3; then compound 1. At a limit, above all of these: compound 4.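

In this assay compound 4 reaches only a limit, > 100000 nM, not a number. With 3-(4-fluorophenyl)-1,2,4-oxadiazol-5-yl held constant, 3-(4-methylpiperidin-1-yl)propoxy to methoxy is now a single measured change, and it gives an at least 96-fold higher number from compound 2 to compound 4 (1.98 log units; beyond the scatter). With methoxy held constant, 3-(4-fluorophenyl)-1,2,4-oxadiazol-5-yl in place of 5-(4-fluorophenyl)-1,3-oxazol-2-yl gives an at least 4.5-fold higher number from compound 1 to compound 4 (0.65 log units; beyond the scatter). Still open, as far as these compounds go, is whether the lower number of compound 2 goes with the 4-methylpiperidine ring or with the propyl chain. A morpholine or a dimethylamine on the same chain, or the same ring on a shorter ethyl chain, would separate the two.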